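The source may hold more compounds than are shown below. What is called first, only, known or untested is meant among the compounds shown, and "the series" means these compounds.

Of the compounds shown here, three have been measured in an assay on IMR-32 cells for displacement of a labelled ligand from corticotropin-releasing factor receptor 1 (Homo sapiens), read by scintillation counting, with a stated time of 2 h; a lower number here means a stronger inhibitor, a higher number a weaker inhibitor. Compound 1 `CCc1nc(NC(CC)CC)c(Cl)nc1-c1ccc(Cl)cc1Cl` gives 71 nM, compound 2 `CCOc1nc(-c2ccc(Cl)cc2Cl)c(CC)nc1NC(CC)CC` gives 151 nM, and compound 3 `CCc1nc(-c2cnc(OC)nc2OC)c(CC)nc1NC(CC)CC` gives 17.2 nM. Compound 2 stands highest of the three, with compound 1 nearest below it and compound 3 furthest. Going by the values given here, the only measured step between compounds differing in one place is a 2.1-fold higher number from compound 1 to compound 2 (0.33 log units; beyond the scatter), ethoxy in place of chloro on an aromatic carbon. Compound 4 `CCc1nc(NC(CC)CC)c(I)nc1-c1ccc(Cl)cc1Cl` differs from compound 2 by iodo in place of ethoxy on an aromatic carbon. Since compound 4 carries a halogen where compound 1 did, that step, read backwards, bears on this change, and a modestly lower number is expected in this assay, an expected step of a 2.5-fold lower number from compound 2 to compound 4 (0.40 log units; beyond the scatter). Compound 4 is accordingly estimated at 60 nM, within a range from 25 nM to 150 nM.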

Compound 4, inhibition constant: 12 nM
Compound 4: the middle estimate sits 5.0-fold (0.70 log units) above what was measured, and the stated range ends above it.
By their numbers in this assay, from the lowest: compounds 4 and 3 (each within the scatter of the next); then compound 1; then compound 2.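

In this assay, this position, next to the ring nitrogen and ortho to the (pentan-3-yl)amino group, proves far more sensitive than the earlier step suggested, with a 13-fold lower number from compound 2 to compound 4 (1.10 log units; beyond the scatter) for iodo in place of ethoxy. The two halogens are also not interchangeable here, since iodo in place of chloro gives a 5.9-fold lower number from compound 1 to compound 4 (0.77 log units; beyond the scatter). Across these three compounds the numbers fall from ethoxy through chloro to iodo, and nothing available accounts for this order. As far as these compounds go, it remains open where bromo, methyl or a nitrile would fall in this order, and whether the gain from iodo would persist with a different aryl group on the core.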